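Pyridin-4-yl in place of furan-2-yl on compound 3

The source may hold more compounds than are shown below. What is called first, only, known or untested is meant among the compounds shown, and "the series" means these compounds.

In a functional assay on DU-145 cells (Homo sapiens) for cytotoxicity, read by ELISA, with a stated time of 2 days (a lower number here means a stronger inhibitor, a higher number a weaker inhibitor), compound 1 (`Oc1cccc(-c2cc(-c3ccccc3)nc(-c3ccco3)c2)c1`) gives 34900 nM and compound 2 (`Oc1cccc(-c2cc(-c3ccccc3)nc(-c3ccncc3)c2)c1`) gives 18100 nM. Compound 3 (`Oc1ccc(-c2cc(-c3ccccc3)nc(-c3ccco3)c2)cc1`) gives 8600 nM, the lowest of the three numbers and beyond the scatter from both others.

Compound 4 (`Oc1ccc(-c2cc(-c3ccccc3)nc(-c3ccncc3)c2)cc1`) is still unmeasured. It carries pyridin-4-yl in place of furan-2-yl on an aromatic carbon of the core of compound 3: pyridin-4-yl in place of furan-2-yl on an aromatic carbon.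

The same exchange has been measured once, in the 3-hydroxyphenyl pair: a 1.9-fold lower number from compound 1 to compound 2 (0.29 log units; within the scatter). That single step is small and gives only a weak lean toward a lower number. The other measured step, 4-hydroxyphenyl in place of 3-hydroxyphenyl, is larger: a 4.1-fold lower number from compound 1 to compound 3 (0.61 log units; beyond the scatter). Applied to compound 2 at 18100 nM, it points to the same region as the exchange applied to compound 3. Going by the values given here, with only one pair behind the exchange, its carry-over to the 4-hydroxyphenyl compounds remains untested.

The expected step is a 1.6-fold lower number from compound 3 to compound 4 (0.19 log units; within the scatter), a slight move toward a lower number and not clearly beyond the scatter in this assay. Compound 4 is estimated at 5500 nM, with an expected range of 2500 nM to 12000 nM.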

Compound 4, half-maximal inhibitory concentration: 2200 nM
For compound 4 the middle estimate is 2.5-fold (0.40 log units) above the measured one; the whole stated range lies above it.
By their numbers in this assay, from the lowest: compound 4; then compound 3; then compounds 2 and 1 (each within the scatter of the next).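

In this assay, going by these compounds alone, pyridin-4-yl in place of furan-2-yl, on the aromatic carbon next to the ring nitrogen, now gives a step beyond the scatter on the 4-hydroxyphenyl compounds, a 3.9-fold lower number from compound 3 to compound 4 (0.59 log units; beyond the scatter), whereas its only earlier reading stayed within the scatter. The exchange keeps its direction on both cores, and the two sizes do not separate: the same change on two cores in this assay, a 1.9-fold lower number (0.29 log units; within the scatter) from compound 1 to compound 2 and a 3.9-fold lower number (0.59 log units; beyond the scatter) from compound 3 to compound 4, 2.0-fold (0.31 log units) apart, within the scatter of two such steps. The 4-hydroxyphenyl for 3-hydroxyphenyl change also holds its direction with pyridin-4-yl in place, an 8.2-fold lower number from compound 2 to compound 4 (0.92 log units; beyond the scatter), so the two changes combine in these four compounds with none going against the pattern, and the sizes of this change again do not separate: the same change on two cores in this assay, a 4.1-fold lower number (0.61 log units; beyond the scatter) from compound 1 to compound 3 and an 8.2-fold lower number (0.92 log units; beyond the scatter) from compound 2 to compound 4, 2.0-fold (0.31 log units) apart, within the scatter of two such steps.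

Within the data shown here, only two groups at this position can be compared here, so it remains open how a plain phenyl, a pyridin-3-yl or a morpholine would read there, and thus whether the place of the ring nitrogen counts. Also open, from the compounds shown here alone, is how a methoxy group in place of the hydroxyl, or an amine or a carboxylic acid on the phenyl group, would move the number in this assay.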